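The compounds below may be only part of what the source reports. "The series", "measured", "known", "first", "only" and "open" are said of these compounds alone.

Measured compounds:
Compound 1, `COc1cc(Cn2cc(CNC(=O)c3cn(-c4ccccc4)nc3-c3ccccc3)nn2)cc(OC)c1OC`: in a functional assay on HeLa cells (Homo sapiens) for antiproliferative activity, read by sulforhodamine B assay, with a stated time of 48 h (on this read-out lower numbers stand for stronger inhibition of growth and higher numbers for weaker inhibition of growth), compound 1 gives only a limit, > 100000 nM.
Compound 2, `COc1ccc(Cn2cc(CNC(=O)c3cn(-c4ccccc4)nc3-c3ccc(F)cc3)nn2)cc1`: compound 2 gives 870 nM.
Compound 3, `COc1ccc(Cn2cc(CNC(=O)c3cn(-c4ccccc4)nc3-c3ccc(F)cc3)nn2)cc1OC`: compound 3 gives 200 nM.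

Compound 3 has the lowest number of the two that are numbers; compound 2 is its nearest neighbour, and the change a 4.4-fold lower number from compound 2 to compound 3 (0.64 log units; beyond the scatter) is beyond the scatter. Compound 4, `COc1cc(Cn2cc(CNC(=O)c3cn(-c4ccccc4)nc3-c3ccc(F)cc3)nn2)cc(OC)c1OC`, is not yet measured. It differs from compound 3 by methoxy in place of hydrogen on an aromatic carbon.

Among the compounds with values here, the one measured step that bears on this, a 4.4-fold lower number from compound 2 to compound 3 (0.64 log units; beyond the scatter), added a methoxy on the same ring and lowered the number modestly. Against it stands compound 1, which carries the same 3,4,5-trimethoxyphenyl as compound 4 and lacks only its fluorine: compound 1 sits at the limit of > 100000 nM in this assay, at which 1 of the 3 values shown sits. Within the data shown here, no step between compound 1 and any other compound is given, so only the two values themselves speak. Weighing the modest gain from the first methoxy against the limit shown by compound 1, the author expects the number to rise, a 100-fold higher number from compound 3 to compound 4 (2.00 log units; beyond the scatter). Compound 4 is therefore estimated at 20000 nM, within a range of 2000 nM to 100000 nM.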

Compound 4, concentration for 50% growth inhibition: 2100 nM
Estimate against measurement, compound 4: 9.5-fold (0.98 log units) above, and the stated range covers the measured number.
By their numbers in this assay, from the lowest: compound 3; then compound 2; then compound 4. At a limit, above all of these: compound 1.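

At this place on the ring, ortho to a methoxy group and meta to a methoxy group, the same change runs the opposite way to the earlier one in this assay: adding a methoxy gave a 4.4-fold lower number from compound 2 to compound 3 (0.64 log units; beyond the scatter), but adding the next gave an 11-fold higher number from compound 3 to compound 4 (1.02 log units; beyond the scatter). The 3,4,5-trimethoxyphenyl therefore ends up worse than the 4-methoxyphenyl as well, with a 2.4-fold higher number from compound 2 to compound 4 (0.38 log units; beyond the scatter), so more methoxy on this ring did not keep lowering the number. Fluoro in place of hydrogen on the other ring still counts with the 3,4,5-trimethoxyphenyl present, giving an at least 47-fold lower number from compound 1 to compound 4 (1.67 log units; beyond the scatter), though that step starts from compound 1, whose value is a limit and not a number: the limit of > 100000 nM in this assay, at which 1 of the 4 values shown sits.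

From the compounds shown here alone, whether the rise belongs to methoxy itself remains open, since a hydroxy, a chlorine or an ethoxy at this place could behave differently. Going by these compounds, how much the fluoro contributes alongside the 3,4-dimethoxyphenyl also stays unknown.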